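The compounds below may be only part of what the source reports. "The series", "measured", "known", "first", "only" and "open" are said of these compounds alone.

Compound 1, `O=C(Nc1ccc(Cl)cc1)Nc1ccc(Nc2ncnc3c2OCCN3)cc1`, gives > 10000 nM in an assay on isolated protein for inhibition of proto-oncogene tyrosine-protein kinase receptor Ret variant V804L (Homo sapiens), read by 33P incorporation, with stated times of 15 min and 40 min (a lower number here means a stronger inhibitor, a higher number a weaker inhibitor), which is a limit of the assay rather than a number.
Compound 2, `COc1cccc(NC(=O)Nc2ccc(Nc3ncnc4c3OCCN4)cc2)c1`, gives > 10000 nM in this assay, again a limit of the assay.
Compound 3, `O=C(Nc1ccc(Nc2ncnc3c2OCCN3)cc1)Nc1cccc2ccccc12`, gives > 10000 nM in this assay, also a limit of the assay.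

Compound 2 therefore stands at the limit, and its two neighbours stand at the same place: the limit of > 10000 nM in this assay, at which 3 of the 3 values shown sit. Because of this, a step that the two limits leave unreadable from compound 1 to compound 2, a step that the two limits leave unreadable from compound 1 to compound 3 and a step that the two limits leave unreadable from compound 2 to compound 3 cannot be read in size or direction; they show only that a 4-chlorophenyl, a 3-methoxyphenyl and a naphthalen-1-yl group on the urea nitrogen all leave the compounds beyond the limit.

Compound 4, `O=C(Nc1ccc(Nc2ncnc3c2OCCN3)cc1)Nc1cccc(-c2ccccc2)c1`, is the next member of the series. It differs from compound 2 by phenyl in place of methoxy on an aromatic carbon. The step from compound 2 to compound 3 is the one that bears most on this change, since both replace the group on that same nitrogen with a larger aromatic one, yet it is unreadable. Among the measured compounds shown here, no measured step therefore gives a direction or size to expect in this assay, and the expectation is that compound 4 stays at the limit as well. Compound 4 is estimated at 15000 nM, with a range from 4000 nM to 60000 nM. The expected step is a step that the limit leaves unreadable from compound 2 to compound 4.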

Compound 4, half-maximal inhibitory concentration: > 10000 nM
Compound 4 was reported as a limit; the forecaster's own chance of this, stated with the estimate: 80%; the middle value is on the limit's open side.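

Among the compounds shown here, compound 4, like compound 2, is reported only as a limit of the assay, so the change from methoxy to phenyl gives no new step that can be read. All the compounds shown stand at one place: the limit of > 10000 nM in this assay, at which 4 of the 4 values shown sit.

The compounds shown leave open how far past that limit each one lies, and which group on the urea nitrogen, if any, would give a measurable value in this assay.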